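The source may hold more compounds than are shown below. What is called first, only, known or untested is meant among the compounds shown, and "the series" means these compounds.

Within the data shown here, in a functional assay on cells (Homo sapiens) for cytotoxicity, read by MTT assay, with a stated time of 24 h (a higher number here means a weaker inhibitor, a lower number a stronger inhibitor), compound 1 (`CCCCCCCCCCCCCCNC(=O)[C@H](CO)/N=C/c1ccc(OC)cc1`) gives 28100 nM, while compound 2 (`CCCCCCCCCCCCCCNC(=O)[C@H](CO)/N=C/c1ccccc1`) gives 7670 nM, the lower of the two numbers measured so far. Compound 3 (`CCCCCCCCCCCCCCNC(=O)[C@H](CO)/N=C/c1cccc(Cl)c1`) differs from compound 2 in one place: chloro in place of hydrogen on an aromatic carbon. This puts chloro in place of hydrogen on an aromatic carbon, meta to a large group. Among the measured compounds shown here, only one measured step bears on this change: a 3.7-fold lower number from compound 1 to compound 2 (0.56 log units; beyond the scatter). That modest step involves methoxy rather than chloro, so it offers a rough scale but no direction for the new group. With so little to go on, no step beyond the scatter is expected in this assay. The estimated step is a 1.2-fold lower number from compound 2 to compound 3 (0.07 log units; within the scatter). For compound 3, the expected value is 6500 nM, with an estimated range of 2800 nM to 16000 nM.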

Compound 3, half-maximal inhibitory concentration: 24100 nM
Compound 3: the middle estimate sits 3.7-fold (0.57 log units) below what was measured, and the stated range ends below it.
By their numbers in this assay, from the lowest: compound 2; then compounds 3 and 1 (each within the scatter of the next).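

In this assay, chloro in place of hydrogen on an aromatic carbon, meta to a large group, brings a 3.1-fold higher number from compound 2 to compound 3 (0.50 log units; beyond the scatter), so compound 2, with its unsubstituted phenyl, now holds the lowest number against both substituted compounds. Exchanging 4-methoxyphenyl for 3-chlorophenyl brings a 1.2-fold lower number from compound 1 to compound 3 (0.07 log units; within the scatter), so these two different groups cannot be told apart in this assay. Nothing shown here accounts for why either group raises the number relative to hydrogen.

Going by these compounds, it remains open whether the rise from hydrogen extends to other groups in the same place, such as fluoro, an amine or a carboxylic acid. Also open, on these data alone, is whether chloro would bring a similar step on a core with a shorter chain.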